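Changing the basic group on the aryl ether: compound 3

The compounds below may be only part of what the source reports. "The series", "measured", "known", "first", "only" and "open" are said of these compounds alone.

Compound 1 `COc1cc(NC(=O)c2ccc(C3CCCCC3)cc2)ccc1OC[C@H]1CCCN1C` gives 79.4 nM in an assay on HEK293 cells for displacement of a labelled ligand from melanin-concentrating hormone receptor 1 (Homo sapiens); a higher number here means a weaker inhibitor, a lower number a stronger inhibitor.
Compound 2 `COc1cc(NC(=O)c2ccc(C3CCCCC3)cc2)ccc1O[C@H]1CCCC[C@@H]1N(C)C` gives 2510 nM in this assay.

Compound 2 stands as the higher of the two numbers, and the step of a 32-fold higher number from compound 1 to compound 2 (1.50 log units; beyond the scatter) is the only measured one. Compound 3 `CCN1CCN(Oc2ccc(NC(=O)c3ccc(C4CCCCC4)cc3)cc2OC)CC1` is not yet measured; it differs from compound 2 by 4-ethylpiperazin-1-yl in place of 2-(dimethylamino)cyclohexyl on an oxygen on an aromatic ring. Going by the values given here, the single measured step concerns the same oxygen but a different exchange of groups, so it bears on compound 3 only loosely. A lower number than compound 2 is expected for compound 3, a 3.1-fold lower number from compound 2 to compound 3 (0.50 log units; beyond the scatter), with wide uncertainty. The estimate for compound 3 is 800 nM, between 150 nM and 4000 nM.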

Compound 3, inhibition constant: 79.4 nM
Compound 3: middle estimate off by 10-fold (1.00 log units), on the high side; the measured number lies below the stated range.
By their numbers in this assay, from the lowest: compounds 1 and 3 (each within the scatter of the next); then compound 2.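

In this assay, the 4-ethylpiperazin-1-yl group on this oxygen shows a 32-fold lower number from compound 2 to compound 3 (1.50 log units; beyond the scatter), whereas the exchange with the (1-methylpyrrolidin-2-yl)methyl group gives no change at the digits printed from compound 1 to compound 3 (within the scatter). Among these three compounds, the loss therefore belongs to the 2-(dimethylamino)cyclohexyl group alone, and replacing (1-methylpyrrolidin-2-yl)methyl does not in itself cost anything at this position. Nothing available explains why these groups differ. The compounds shown leave open whether the ethyl on the piperazine matters, as a piperazine carrying a methyl or a morpholine ring might show.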